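This account rests on a few compounds, and the source may have more. Where it says the series, first, only, none or still open, it means among the compounds named here.

In an ADME assay on S9 fraction from liver (Rattus norvegicus) for metabolic stability, read by LC-MS, using NADPH, with a stated time of 30 min (on this read-out lower numbers stand for a less stable compound and higher numbers for a more stable compound), compound 1 `CCCCCCCCc1ccc(OCC(=O)Cn2nnc(C)n2)cc1` gives < 5%, which is a limit of the assay and not a number. Among the measured compounds shown here, compound 2 `CCCCCCCCc1ccc(OCC(=O)Cn2nnc(-c3ccc(Cl)cc3)n2)cc1` gives 74%, the only actual number so far. For the measured compounds named here, the sole measured step is a number at least 69 percentage points higher from compound 1 to compound 2 (beyond the scatter), and it came with 4-chlorophenyl in place of methyl on an aromatic carbon. Compound 3 `CCCCCCCCc1ccc(OCC(=O)Cn2nnc(-c3ccc(S(=O)(=O)N(C)C)cc3)n2)cc1` keeps the phenyl part of that group but carries dimethylsulfamoyl in place of chloro on an aromatic carbon, para to a large group: dimethylsulfamoyl in place of chloro on an aromatic carbon. The measured step bears on this change only in part, as it replaced methyl with the whole 4-chlorophenyl group and did not test a different group on that phenyl. With the phenyl part kept, much of the high reading of compound 2 at 74% is expected to remain, with a moderate fall far smaller than the measured step. The expected change in this assay is a number 14 percentage points lower from compound 2 to compound 3 (beyond the scatter). For compound 3 the estimate is 60%, with an expected range of 28% to 88%.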

Compound 3, percent of the compound remaining: 65%
Beside the measured number, compound 3's estimate is 5 percentage points below it; measured number inside the range.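

Changing chloro (1 heavy atom) to dimethylsulfamoyl (6 heavy atoms) on the phenyl ring gives a number 9 percentage points lower from compound 2 to compound 3 (within the scatter) in this assay, so the high reading of compound 2 does not depend on the chloro group itself. A second substituted phenyl group at this position also reads far above the methyl compound, with a number at least 60 percentage points higher from compound 1 to compound 3 (beyond the scatter), so the large rise is now seen with two different phenyl groups and not just one. Compound 1 sits at a limit of the assay, so the true size of each rise from it remains unknown, which is why those steps are given only as minimum sizes: the limit of < 5% in this assay, at which 1 of the 3 values shown sits.

On these data alone, both phenyl compounds carry a group on that ring, so it remains open whether the bare phenyl ring would be enough or whether a group on it is needed. As far as these compounds go, it also remains open whether the reading would hold with a charged group such as a carboxylic acid or an amine in place of dimethylsulfamoyl, and how far other parts of the shared core contribute.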